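Pyrazole swap on the shared core: compound 1 to compound 3

The compounds below may be only part of what the source reports. "The series", "measured", "known", "first", "only" and "open" are said of these compounds alone.

Measured in a physicochemical assay for lipophilicity, using the shake flask method, in phosphate buffer, measured as octanol-water partition, at pH 7.4; on this read-out higher numbers stand for higher lipophilicity and lower numbers for lower lipophilicity:
- compound 1 `Cn1ccc(-c2cn3nccc3c(-c3cnn([C@]4(CC#N)C[C@@H](C#N)C4)c3)n2)n1` gives 1.6
- compound 2 `Cn1ccc(-c2cn3nccc3c(-c3cnn([C@]4(CC#N)C[C@H](C#N)C4)c3)n2)n1` gives 1.6

Compound 1 stands level with compound 2 at the digits shown. Compound 3 `N#CC[C@]1(n2cc(-c3nc(-c4cn[nH]c4)cn4nccc34)cn2)C[C@H](C#N)C1` carries 1H-pyrazol-4-yl in place of 1-methyl-1H-pyrazol-3-yl on an aromatic carbon. Among the compounds with values here, the only measured step, no change at the digits printed from compound 1 to compound 2 (within the scatter), offers no size for this change because of the fact that compounds 1 and 2 differ only in the configuration as drawn. A modest fall in this assay is therefore expected from the structural change alone, starting from compound 1 at 1.6. The expected change is a number 0.40 log units lower from compound 1 to compound 3 (beyond the scatter). For compound 3 the estimate is 1.2, with an expected range of 0.7 to 1.7.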

Compound 3, distribution coefficient: 1.7
Estimate against measurement, compound 3: 0.50 log units below; measured number inside the range.
By their numbers in this assay, from the lowest: compounds 1, 2 and 3 (each within the scatter of the next).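

Within the data shown here, at this aromatic carbon, 1H-pyrazol-4-yl in place of 1-methyl-1H-pyrazol-3-yl gives a number 0.10 log units higher from compound 1 to compound 3 (within the scatter) in this assay, the first step here that alters the structure rather than the configuration as drawn. This position therefore accepts the exchange of a group with 0 hydrogen-bond donors for one with 1 hydrogen-bond donor without a step beyond the scatter. Nothing measured here accounts for this result.

Still open, from the compounds shown here alone, is whether 1-methyl-1H-pyrazol-4-yl would separate the ring attachment from the methyl group. Also open, going by these compounds, is whether an amine or a carboxylic acid on this carbon would give a step beyond the scatter.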